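Methyl on the ring nitrogen: a repeated step toward compound 4

The compounds below may be only part of what the source reports. "The series", "measured", "known", "first", "only" and "open" are said of these compounds alone.

The study compares four compounds that share a five-membered aromatic ring with 2 nitrogen, part of a fused or bridged system of two rings, carrying an amino group, in an assay on isolated protein for inhibition of serine/threonine-protein kinase Chk2 (Homo sapiens), read by mobility shift assay, tested at 30 uM; on this read-out lower numbers stand for less inhibition and higher numbers for more inhibition at the one concentration tested (going by the name of the read-out). Compound 1 `Nc1n[nH]c2cc(-c3ccccn3)[nH]c(=O)c12` gives 47% in this assay. Compound 3 `Cn1nc(N)c2c(=O)[nH]c(-c3ccccn3)cc21` gives 25% in this assay. The change from compound 1 to compound 3 is methyl in place of hydrogen on an aromatic nitrogen, and its effect is a number 22 percentage points lower from compound 1 to compound 3 (beyond the scatter).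

Compound 2 `Cc1cc2[nH]nc(N)c2c(N2CCCCC2)n1` gives 33% in this assay. How the core of compound 2 differs from the core of compound 1 is not broken down here. The values of compound 2 and compound 3 lie within the usual scatter of each other, while compound 1 shows a higher number than compound 2.

Compound 4 `Cc1cc2c(c(N)nn2C)c(N2CCCCC2)n1` has not yet been measured in this assay. It differs from compound 2 by methyl in place of hydrogen on an aromatic nitrogen, which is the same change as that from compound 1 to compound 3, made at the same place. Within the data shown here, the step from compound 2 to compound 4 is expected to be a number 19 percentage points lower from compound 2 to compound 4 (beyond the scatter), because a number 22 percentage points lower from compound 1 to compound 3 (beyond the scatter) is the only measured instance of this change and is the basis for the expectation. Compound 4 is therefore estimated to give about 14% in this assay, within a range from 2% to 28%.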

Compound 4, a percentage reported as inhibition, at one concentration (the size of the read-out at that concentration, not a potency): 4%
Beside the measured number, compound 4's estimate is 10 percentage points above it; measured number inside the range.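

In this assay, methyl in place of hydrogen on an aromatic nitrogen gives a number 29 percentage points lower from compound 2 to compound 4 (beyond the scatter). The change therefore carries over from the core of compound 1 to the core of compound 2, with the number falling on both cores and the two steps not told apart in size: the same change on two cores in this assay, a number 22 percentage points lower (beyond the scatter) from compound 1 to compound 3 and a number 29 percentage points lower (beyond the scatter) from compound 2 to compound 4, 7 percentage points apart, within the scatter of two such steps. Among these compounds, this rests on only two matched pairs and a percentage at one concentration, so it does not show that the step would hold on a third core or with other groups elsewhere on these two, and it says nothing about potency or about why the number falls.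

The compounds shown leave open whether an ethyl group, a longer chain or a chain ending in an amine on the same nitrogen would give a step like that of methyl. They also leave open whether the lower numbers go with the loss of the hydrogen or with the presence of the methyl, as each of the two steps replaces the one with the other.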